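Replacing the Hydroxyalkyl Ester Chain with Furan-3-yl

A few compounds are considered here, and "the series" means these few. Any claim that something is new, unique, unknown or untested is made for them only; others in the source may bear on it.

Measured in a functional assay on DU-145 cells (Homo sapiens) for cytotoxicity, read by MTT assay; on this read-out higher numbers stand for weaker inhibition and lower numbers for stronger inhibition:
- compound 1 `CC[C@](C)(O)CC(=O)O[C@H](CC=C(C)C)C1=CC(=O)c2c(O)ccc(O)c2C1=O`: 20500 nM
- compound 2 `CC(C)=CC[C@@H](OC(=O)CC(C)(O)C(C)C)C1=CC(=O)c2c(O)ccc(O)c2C1=O`: 16900 nM
- compound 3 `CCCCC(C)(O)CC(=O)O[C@H](CC=C(C)C)C1=CC(=O)c2c(O)ccc(O)c2C1=O`: 76500 nM

Among these three, compound 3 gives the highest number, 76500 nM. Compound 4 `CC(C)=CC[C@@H](OC(=O)c1ccoc1)C1=CC(=O)c2c(O)ccc(O)c2C1=O` carries furan-3-yl in place of 2-hydroxy-2-methylhexyl on a carbonyl carbon. Going by the values given here, two measured steps bear on this change: a 3.7-fold higher number from compound 1 to compound 3 (0.57 log units; beyond the scatter) and a 4.5-fold higher number from compound 2 to compound 3 (0.66 log units; beyond the scatter). The third, a 1.2-fold lower number from compound 1 to compound 2 (0.08 log units; within the scatter), shows no separation between compound 1 and compound 2. Among the compounds with values here, no measured compound carries furan-3-yl, so this reading is only a rough guide. A modest step to a lower number is therefore expected in this assay, estimated as a 3.5-fold lower number from compound 3 to compound 4 (0.54 log units; beyond the scatter). Compound 4 is estimated at 22000 nM, with an expected range of 6000 nM to 80000 nM.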

Compound 4, half-maximal inhibitory concentration: > 100000 nM
Compound 4: no number, only a limit; the forecaster's own chance of this, stated with the estimate: 5%; middle value at least 4.5-fold (0.65 log units) away from the limit.
By their numbers in this assay, from the lowest: compounds 2 and 1 (each within the scatter of the next); then compound 3. At a limit, above all of these: compound 4.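

In this assay, compound 4 gives only a limit of the assay: the limit of > 100000 nM in this assay, at which 1 of the 4 values shown sits. Furan-3-yl on this carbonyl carbon gives an at least 5.9-fold higher number from compound 2 to compound 4 (0.77 log units; beyond the scatter) and an at least 4.8-fold higher number from compound 1 to compound 4 (0.68 log units; beyond the scatter), so this position, which held measurable numbers with all three hydroxyalkyl chains, does not accept this ring without a clear loss. The result also reads as an at least 1.3-fold higher number from compound 3 to compound 4 (0.11 log units; that floor lies within the scatter), a floor within the scatter, so the size of that step stays unresolved.

The compounds shown leave open whether the ring or the missing hydroxyl accounts for the loss, as both change together here. A plain butyl chain without hydroxyl on the same carbonyl carbon would separate the two.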